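Aryl substituent variation on the shared core: outlook for compound 3

This account rests on a few compounds, and the source may have more. Where it says the series, first, only, none or still open, it means among the compounds named here.

Measured so far in an assay for binding affinity to adenosine receptor A1 (Bos taurus); on this read-out lower numbers stand for stronger inhibition and higher numbers for weaker inhibition:
compound 1 `Cn1c(=O)c2nc(-c3ccc(I)cc3)[nH]c2n(C)c1=O`: 1.3 nM
compound 2 `Cn1c(=O)c2nc(-c3ccc(F)cc3)[nH]c2n(C)c1=O`: 3.5 nM

Compound 2 holds the higher of the two numbers in this assay; its nearest neighbour is compound 1, and the step of a 2.7-fold higher number from compound 1 to compound 2 (0.43 log units; beyond the scatter) lies beyond the usual scatter, so the fluoro analogue is the weaker of the measured pair.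

Compound 3 `Cn1c(=O)c2nc(-c3ccc(-c4ccccc4)cc3)[nH]c2n(C)c1=O` has not yet been measured. It differs from compound 2 as follows: phenyl in place of fluoro on an aromatic carbon.

Going by the values given here, no measured step covers this exact exchange. Among the compounds with values here, the only step that bears on it is a 2.7-fold higher number from compound 1 to compound 2 (0.43 log units; beyond the scatter), where replacing iodo with fluoro on the same aromatic carbon gave a modest rise in the number. Going from fluoro to phenyl moves further from the fluoro end of that pair, so a step in the opposite direction, toward lower numbers, is the expectation, though its size is uncertain without a phenyl precedent. The estimated step of a 2.3-fold lower number from compound 2 to compound 3 (0.37 log units; beyond the scatter) is therefore expected to be modest. For compound 3 the estimate in this assay is 1.5 nM, expected within 0.4 nM to 6 nM.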

Compound 3, half-maximal inhibitory concentration: 3.5 nM
The estimate for compound 3 lay 2.3-fold (0.37 log units) below the measured number; the measured number falls inside the stated range.
By their numbers in this assay, from the lowest: compound 1; then compounds 2 and 3 (each within the scatter of the next).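

In this assay, phenyl in place of fluoro on this aromatic carbon gives no change at the digits printed from compound 2 to compound 3 (within the scatter), so exchanging a single fluorine for a group of 6 heavy atoms with a six-membered aromatic ring of its own does not separate the two compounds on this read-out. Phenyl in place of iodo gives a 2.7-fold higher number from compound 1 to compound 3 (0.43 log units; beyond the scatter), which leaves compound 1 apart from both other compounds, whereas the earlier pair alone could not show that a group as different from fluoro as phenyl would remain within the scatter of compound 2. Nothing available on these compounds accounts for compound 1 standing apart at this position.

Going by these compounds, it remains open whether the match between fluoro and phenyl holds for groups of a different kind on this aromatic carbon, such as an amine, a carboxylic acid or a longer alkyl chain. On these data alone, it is also open whether a phenyl group bearing a substituent of its own, such as a methoxy group, would stay within the scatter of compound 3 or move toward compound 1.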